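This account rests on a few compounds, and the source may have more. Where it says the series, first, only, none or still open, it means among the compounds named here.

Compound 1 `CC1=C(C(=O)Nc2ccc(Br)cc2)C(c2ccc(Cl)cc2Cl)N=C(SCc2ccccc2)N1` gives the lowest of the three numbers measured in a functional assay on the whole organism (artery, strain albino) with Rattus norvegicus as the target, with a stated time of 240 min, at a dose of 10 mg/kg by the oral route; on this read-out lower numbers stand for less inhibition and higher numbers for more inhibition at the one dose given (going by the name of the read-out): compound 1 gives 17.4%, while compound 2 `CC1=C(C(=O)Nc2ccc(Br)cc2)C(c2ccc(Cl)cc2Cl)N=C(SCc2ccccc2Cl)N1` gives 28.7% and compound 3 `CC1=C(C(=O)Nc2ccc(Br)cc2)C(c2ccc(Cl)cc2Cl)N=C(SCc2ccc(F)cc2)N1` gives 36.4%. The steps of a number 11.3 percentage points higher from compound 1 to compound 2 (beyond the scatter) and a number 19 percentage points higher from compound 1 to compound 3 (beyond the scatter) both alter the benzylsulfanyl group, and the step of a number 7.7 percentage points higher from compound 2 to compound 3 (within the scatter) stays within the scatter. Compound 4 `COc1ccc(C2N=C(SCc3ccccc3)NC(C)=C2C(=O)Nc2ccc(Br)cc2)cc1` differs from compound 1 in 4-methoxyphenyl in place of 2,4-dichlorophenyl on a saturated ring carbon. Among the measured compounds shown here, none of the measured steps touches this saturated ring carbon, so the three steps give no direct guide to the change, and in this assay no step beyond the scatter in either direction is expected. Compound 4 is therefore expected to give 20%, between 5% and 40%, with an expected step of a number 2.6 percentage points higher from compound 1 to compound 4 (within the scatter).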

Compound 4, a percentage reported as inhibition, in the whole organism at one dose (the size of the read-out at that dose, not a potency): 13.3%
Compound 4: the middle estimate sits 6.7 percentage points above what was measured, within the range that was stated.
By their numbers in this assay, from the lowest: compounds 4 and 1 (each within the scatter of the next); then compounds 2 and 3 (each within the scatter of the next).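

With 4-methoxyphenyl in place of 2,4-dichlorophenyl on the saturated ring carbon, this assay gives a number 4.1 percentage points lower from compound 1 to compound 4 (within the scatter), so this first change at the position does not separate the two groups at the one dose given. Both chlorines can thus be exchanged for one methoxy group without a step beyond the scatter, unlike the two steps beyond the scatter on the benzylsulfanyl group. Nothing given here bears on why this is so.

The compounds shown leave open how an amine or a carboxylic acid on this phenyl ring would read. They also leave open whether the exchange would read the same alongside the 4-fluorophenyl of compound 3.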